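Removing both halogens from the anilino group of compound 2

The compounds below may be only part of what the source reports. "The series", "measured", "known", "first", "only" and "open" are said of these compounds alone.

Of the compounds shown here, two that share a common core have been measured in a functional assay on A549 cells (Homo sapiens) for antiproliferative activity, read by MTT assay, with a stated time of 72 h; a higher number here means a weaker inhibitor, a lower number a stronger inhibitor. Compound 1 `COc1cc2ncnc(Nc3cccc(Br)c3)c2cc1OCCCCC(=O)Nc1ccc(S(N)(=O)=O)cc1` gives 14900 nM in this assay, and compound 2 `COc1cc2ncnc(Nc3cccc(Cl)c3F)c2cc1OCCCCC(=O)Nc1ccc(S(N)(=O)=O)cc1` gives 10500 nM. Among the measured compounds shown here, the only change between them, a 3-chloro-2-fluorophenyl in place of a 3-bromophenyl on a nitrogen on an aromatic ring, produced a 1.4-fold lower number from compound 1 to compound 2 (0.15 log units; within the scatter), so compound 2 stands within the scatter of the only other number available.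

Compound 3 `COc1cc2ncnc(Nc3ccccc3)c2cc1OCCCCC(=O)Nc1ccc(S(N)(=O)=O)cc1` is not yet measured. It differs from compound 2 by phenyl in place of 3-chloro-2-fluorophenyl on a nitrogen on an aromatic ring. For the measured compounds named here, the single step so far, a 1.4-fold lower number from compound 1 to compound 2 (0.15 log units; within the scatter), swapped one halogenated ring for another and did not move the number beyond the scatter; no measured step removes all substituents from that ring. The expected step is therefore small, with a slight lean towards a higher number, a 1.9-fold higher number from compound 2 to compound 3 (0.28 log units; within the scatter), a change not clearly beyond the scatter. Compound 3 is estimated at 20000 nM, with a range from 8000 nM to 50000 nM.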

Compound 3, half-maximal inhibitory concentration: > 40000 nM
Compound 3 was reported as a limit; the forecaster's own chance of this, stated with the estimate: 10%; at least 2.0-fold (0.30 log units) between middle value and limit.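

Compound 3 is reported only as a limit, not a number, in this assay: the limit of > 40000 nM in this assay, at which 1 of the 3 values shown sits.

Even so, the bare anilino group gives an at least 3.8-fold higher number from compound 2 to compound 3 (0.58 log units; beyond the scatter), and an at least 2.6-fold higher number from compound 1 to compound 3 (0.42 log units; beyond the scatter), whereas exchanging one halogenated ring for the other gave only a 1.4-fold lower number from compound 1 to compound 2 (0.15 log units; within the scatter). The earlier pair could not show that at this place, on the nitrogen on the aromatic ring, having halogen on the ring matters more to the number in this assay than which halogen pattern is present, and the limit leaves the full size of the loss unknown.

The compounds shown leave open whether a single fluoro or chloro group on the ring would be enough to keep the lower numbers. They also leave open whether a methyl, methoxy or nitrile group could stand in for the halogens.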